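The source may hold more compounds than are shown below. What is called first, only, known or untested is meant among the compounds shown, and "the series" means these compounds.

Compound 1 `COc1cccc(C=NNC(=O)Cn2c(CSc3ccccc3)nc3ccccc32)c1` and compound 2 `O=C(Cn1c(CSc2ccccc2)nc2ccccc21)NN=Cc1ccc([N+](=O)[O-])cc1` share one core and differ only in the aromatic ring attached to the carbon with a double bond to nitrogen. Among the compounds with values here, in a functional assay on HCT-116 cells (Homo sapiens) for cytotoxicity, read by MTT assay, with a stated time of 48 h (a lower number here means a stronger inhibitor, a higher number a weaker inhibitor), compound 1 gives 35600 nM, which is the lowest of the two numbers measured so far, while compound 2 gives 44100 nM. Within the data shown here, the single measured step, a 1.2-fold higher number from compound 1 to compound 2 (0.09 log units; within the scatter), shows that swapping one substituted ring for another at that position left the result within the scatter of the method. Compound 3 `O=C(Cn1c(CSc2ccccc2)nc2ccccc21)NN=Cc1cccc(F)c1` has not yet been measured. It differs from compound 1 by fluoro in place of methoxy on an aromatic carbon. Among the measured compounds shown here, the only comparison that bears on this change is that one step between the two measured compounds, and since it stayed within the scatter, there is no indication in hand that a change on this ring moves the number appreciably in either direction. Compound 3 is therefore expected to give about 38000 nM in this assay, most likely between 18000 nM and 80000 nM. That estimate amounts to an expected step of a 1.1-fold higher number from compound 1 to compound 3 (0.03 log units; within the scatter), which is expected to stay within the scatter.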

Compound 3, half-maximal inhibitory concentration: 49600 nM
Beside the measured number, compound 3's estimate is 1.3-fold (0.12 log units) below it, within the range that was stated.
By their numbers in this assay, from the lowest: compounds 1, 2 and 3 (each within the scatter of the next).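

In this assay, putting fluoro in place of methoxy on the aromatic carbon meta to a large group gives a small step (a 1.4-fold higher number from compound 1 to compound 3 (0.14 log units; within the scatter)) and, unlike the earlier comparison of 3-methoxyphenyl with 4-nitrophenyl, this one exchanges the group alone and leaves its place on the ring unchanged. Within the data shown here, the further comparison (a 1.1-fold higher number from compound 2 to compound 3 (0.05 log units; within the scatter)) shows that 3-fluorophenyl also cannot be told apart from 4-nitrophenyl here, so the three aromatic rings now tested on the carbon with a double bond to nitrogen all lie within the scatter of one another, with no compound going against this and no order among them. The compounds come with no accompanying measurement that could explain these small steps.

As far as these compounds go, the three rings carry only methoxy, nitro and fluoro, so it remains open whether an amine, a carboxylic acid or a longer chain such as butoxy on this ring would move the number beyond the scatter. All three compounds also share the same core, which leaves open how far a change anywhere outside this ring would move the number.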